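Second chloro on compound 2 gives compound 4

The source may hold more compounds than are shown below. What is called first, only, known or untested is meant among the compounds shown, and "the series" means these compounds.

Compound 1 `COc1cc2c(Oc3ccc(NC(=O)c4nn(-c5ccccc5)c(=O)cc4C)cc3F)ccnc2cc1OCCCN1CCN(C)CC1` is the reference of the set. In a functional assay on U-87MG ATCC cells (Homo sapiens) for inhibition, read by MTT assay, with a stated time of 72 h (on this read-out lower numbers stand for stronger inhibition and higher numbers for weaker inhibition), compound 1 gives 2120 nM. Compound 3 `COc1cc2c(Oc3ccc(NC(=O)c4nn(-c5ccc(Cl)cc5)c(=O)cc4C)cc3F)ccnc2cc1OCCCN1CCN(C)CC1` differs from compound 1 in one place, (chloro in place of hydrogen on an aromatic carbon), and in this assay compound 3 gives 1560 nM, so that a 1.4-fold lower number from compound 1 to compound 3 (0.13 log units; within the scatter). Compound 2 `COc1cc2c(Oc3ccc(NC(=O)c4nn(-c5ccc(Cl)cc5)c(=O)cc4C)cc3F)ccnc2cc1OCCCN1CCCCC1` gives 1400 nM in this assay; from compound 2 to compound 3 the change is 4-methylpiperazin-1-yl in place of piperidin-1-yl on a saturated chain carbon, three bonds along the chain from an oxygen on an aromatic ring, and a 1.1-fold higher number from compound 2 to compound 3 (0.05 log units; within the scatter). How the core of compound 2 differs from the core of compound 1 is not broken down here. All three measured numbers lie within the scatter of one another.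

Compound 4 `COc1cc2c(Oc3ccc(NC(=O)c4nn(-c5ccc(Cl)cc5Cl)c(=O)cc4C)cc3F)ccnc2cc1OCCCN1CCCCC1` has not been measured. It differs from compound 2 by chloro in place of hydrogen on an aromatic carbon. This is the same kind of change as that from compound 1 to compound 3, but not the same: in compound 3 the entering chloro sits para to a large group, whereas in compound 4 it sits ortho to a large group and meta to a chloro group. Going by the values given here, the one measured instance, a 1.4-fold lower number from compound 1 to compound 3 (0.13 log units; within the scatter), stayed within the scatter, so a step of about a 1.2-fold lower number from compound 2 to compound 4 (0.07 log units; within the scatter) is expected in this assay, resting on that single precedent in compound 1 and compound 3 and on no other data. Compound 4 is accordingly estimated at 1200 nM in this assay, with a likely range from 550 nM to 2600 nM.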

Compound 4, half-maximal inhibitory concentration: 1800 nM
Beside the measured number, compound 4's estimate is 1.5-fold (0.18 log units) below it; the measured number falls inside the stated range.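

In this assay, going by these compounds alone, the second chloro on the aryl ring gives a 1.3-fold higher number from compound 2 to compound 4 (0.11 log units; within the scatter), so on this read-out the change from 4-chlorophenyl to 2,4-dichlorophenyl leaves no step that can be told from the scatter. Set beside the earlier chloro step, the two instances give no sign that the change behaves differently from one core to the other: the same change on two cores in this assay, a 1.4-fold lower number (0.13 log units; within the scatter) from compound 1 to compound 3 and a 1.3-fold higher number (0.11 log units; within the scatter) from compound 2 to compound 4, 1.7-fold (0.24 log units) apart, within the scatter of two such steps. This does not show that the change carries over as a fixed step, for the two steps are small, they have opposite signs, and the entering chloro in compound 4 sits ortho to a large group and meta to a chloro group, a place not matched in the step to compound 3.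

The compounds shown leave open whether any other group on this aryl ring, such as trifluoromethyl or nitrile, would give a step beyond the scatter. They also leave open whether a different amine at the end of the side chain, such as morpholin-4-yl or a primary amine, would do so.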